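Amide heteroaryl swaps on the shared core: imidazole variants

The compounds below may be only part of what the source reports. "The series", "measured", "known", "first", "only" and "open" are said of these compounds alone.

Compound 1 `COc1cc(N(C)C)c(NC(=O)c2ncccn2)cc1Nc1nccc(-c2cn(C)c3ccccc23)n1` and compound 2 `COc1cc(N(C)C)c(NC(=O)c2c[nH]cn2)cc1Nc1nccc(-c2cn(C)c3ccccc23)n1` share one core and differ only in the aromatic group carried on the amide carbonyl carbon. In a functional assay on NCI-H1975 cells (Homo sapiens) for antiproliferative activity, read by MTT assay, with a stated time of 72 h (a lower number here means a stronger inhibitor, a higher number a weaker inhibitor), compound 1 gives 5400 nM, and in the same assay compound 2 gives 3120 nM. Among the compounds with values here, the step of a 1.7-fold lower number from compound 1 to compound 2 (0.24 log units; within the scatter) is the only measured step in the set. Compound 2 therefore holds the lower of the two numbers, but since the gap to compound 1 stays within the scatter, no order between the two is claimed.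

Compound 3 `COc1cc(N(C)C)c(NC(=O)c2nccn2C)cc1Nc1nccc(-c2cn(C)c3ccccc23)n1` has not yet been measured. The change from compound 2 is 1-methyl-1H-imidazol-2-yl in place of 1H-imidazol-4-yl on a carbonyl carbon. Within the data shown here, the single step that bears on it is the earlier exchange on the same carbonyl carbon, a 1.7-fold lower number from compound 1 to compound 2 (0.24 log units; within the scatter), which did not move the read-out beyond the scatter. On that basis a further heteroaryl exchange at this carbonyl carbon is expected to give no step beyond the scatter, that is a 1.1-fold higher number from compound 2 to compound 3 (0.05 log units; within the scatter). For compound 3 the estimated value in this assay is 3500 nM, with an expected range from 1200 nM to 10000 nM.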

Compound 3, half-maximal inhibitory concentration: 2880 nM
Compound 3: the middle estimate sits 1.2-fold (0.08 log units) above what was measured, and the stated range covers the measured number.
By their numbers in this assay, from the lowest: compounds 3, 2 and 1 (each within the scatter of the next).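

At this carbonyl carbon, the exchange of 1H-imidazol-4-yl for 1-methyl-1H-imidazol-2-yl gives, in this assay, a 1.1-fold lower number from compound 2 to compound 3 (0.03 log units; within the scatter), so a change from 1 hydrogen-bond donor to 0 and from 1 hydrogen-bond acceptor to 2, together with an added methyl group and a different ring attachment point, does not move the read-out beyond the scatter. The exchange of pyrimidin-2-yl for 1-methyl-1H-imidazol-2-yl at the same carbon gives a 1.9-fold lower number from compound 1 to compound 3 (0.27 log units; within the scatter), so all three aromatic groups at this carbonyl carbon remain within the scatter of one another in this series, and no order among them is supported. No measurement at hand bears on why these exchanges leave the read-out within the scatter.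

On these data alone, whether a group of another type on this carbonyl carbon, such as an aminomethyl group, a carboxylic acid on a short chain or a plain butyl chain, would give a step beyond the scatter remains open. Also open, as far as these compounds go, is whether the same exchanges would stay within the scatter on a core carrying a different group in place of the dimethylamino group.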